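Cyclopropyl to cyclobutyl on the side-chain amide

The compounds below may be only part of what the source reports. "The series", "measured", "known", "first", "only" and "open" are said of these compounds alone.

Among the measured compounds shown here, compound 1 `Cn1ncc(Cl)c1-c1cc(C(=O)N[C@@H]2CN[C@H](CC(=O)NC3CC3)C[C@H]2c2ccc(Cl)c(Cl)c2)oc1Cl` gives 3.95 nM in an assay for inhibition of RAC-alpha serine/threonine-protein kinase (Homo sapiens), read by HTRF, with a stated time of 1 h (on this read-out lower numbers stand for stronger inhibition and higher numbers for weaker inhibition), the lower of the two numbers measured so far. For the measured compounds named here, compound 2 `Cn1ncc(Cl)c1-c1cc(C(=O)NC2CNCC2c2ccc(C(F)(F)F)cc2)oc1Cl` gives 538 nM in this assay, a far higher number, but the two structures differ in several places at once, so no single step is drawn between them. Compound 3 `Cn1ncc(Cl)c1-c1cc(C(=O)N[C@@H]2CN[C@H](CC(=O)NC3CCC3)C[C@H]2c2ccc(Cl)c(Cl)c2)oc1Cl` has not been measured. It differs from compound 1 in one place (cyclobutyl in place of cyclopropyl on an amide-type nitrogen), cyclopropylcarbamoyl becoming cyclobutylcarbamoyl. Neither measured compound speaks to this exchange, so the step expected from compound 1 to compound 3 a 1.1-fold higher number from compound 1 to compound 3 (0.06 log units; within the scatter) is small, within the usual scatter, with no clear direction. Compound 3 is therefore expected to give about 4.5 nM in this assay, with a range from 2 nM to 11 nM. The anchor for this expectation is compound 1 at 3.95 nM.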

Compound 3, half-maximal inhibitory concentration: 7.98 nM
Estimate against measurement, compound 3: 1.8-fold (0.25 log units) below; the range from low to high includes it.
By their numbers in this assay, from the lowest: compound 1; then compound 3; then compound 2.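

In this assay, among the compounds shown here, cyclobutyl in place of cyclopropyl on the amide-type nitrogen gives a 2.0-fold higher number from compound 1 to compound 3 (0.31 log units; beyond the scatter) as the only single-place step in the set, so this position does respond to exchanging a three-membered carbon ring for a four-membered one. The step is modest, and the side chain tolerates the larger ring, with compound 3 still at 7.98 nM in this read-out. Nothing measured on these compounds accounts for the step, so its origin stays unassigned.

As far as these compounds go, one step gives a direction for a single pair and no trend, so whether cyclopentyl, an open chain such as isopropyl, or a ring-free amide with the hydrogen alone would continue it remains open. Also open, from the compounds shown here alone, is how a carboxylic acid or an amine in place of the cyclopropylcarbamoyl group would read.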